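Amide series: diethylamino in place of benzyloxy

The compounds below may be only part of what the source reports. "The series", "measured", "known", "first", "only" and "open" are said of these compounds alone.

Within the data shown here, compound 2 `O=C(NCCO)c1cc2ccc(OCc3ccccc3)cc2oc1=O` carries the only number so far in a functional assay on HCT-116 cells (Homo sapiens) for cytotoxicity, read by MTT assay, with a stated time of 72 h; on this read-out lower numbers stand for stronger inhibition and higher numbers for weaker inhibition: compound 2 gives 18700 nM. Compound 1 `CCCOc1ccc2cc(C(=O)NCCO)c(=O)oc2c1` sits at a limit of this assay, > 100000 nM; this is the limit of > 100000 nM in this assay, at which 1 of the 2 values shown sits. Among the measured compounds shown here, the one measured step, an at least 5.3-fold lower number from compound 1 to compound 2 (0.72 log units; beyond the scatter), is all that bears on the next change. Compound 3 `CCN(CC)c1ccc2cc(C(=O)NCCO)c(=O)oc2c1` differs from compound 2 by diethylamino in place of benzyloxy on an aromatic carbon. The aromatic ring gained in the step from compound 1 to compound 2 is lost again here, so a weakening, expected as a 2.7-fold higher number from compound 2 to compound 3 (0.43 log units; beyond the scatter), seems likely, with a real chance of a limit only. Compound 3 is estimated at 50000 nM (range 15000 nM to 200000 nM).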

Compound 3, half-maximal inhibitory concentration: > 100000 nM
Compound 3: no number, only a limit; the forecaster's own chance of this, stated with the estimate: 40%; at least 2.0-fold (0.30 log units) between middle value and limit.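

In this assay, diethylamino in place of benzyloxy on this aromatic carbon gives an at least 5.3-fold higher number from compound 2 to compound 3 (0.72 log units; beyond the scatter). A second group without a ring now fails to give a readable number, so among the three groups at this position only benzyloxy, with its six-membered aromatic ring of carbon only, gives one: the limit of > 100000 nM in this assay, at which 2 of the 3 values shown sit. The step from compound 1 to compound 3 cannot be read: both values are limits.

Still open, from the compounds shown here alone, is whether the ring alone carries the gain, or also its link to the core. A phenyl set directly on the aromatic carbon, a phenethoxy group or a cyclic amine such as morpholine would separate these.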